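Dropping the urea link: from compound 2 to compound 4

The source may report more compounds than this note shows. Statements on the series, on what has been measured and on what is new or still open speak of the compounds shown alone.

Measured so far:
compound 1 `COc1ncc(-c2ccc3nc(NC(=O)NC4CC4)sc3c2)cc1NS(=O)(=O)c1ccc(F)cc1` — 520 nM
compound 2 `COc1ncc(-c2ccc3nc(NC(=O)NCCN4CCCCC4)sc3c2)cc1NS(=O)(=O)c1ccc(F)cc1` — 750 nM
compound 3 `CCCNc1nc2ccc(-c3cnc(Cl)c(NS(=O)(=O)c4ccc(F)cc4)c3)cc2s1` — "not determined" (no result reported)

For the measured compounds named here, in a functional assay on U-87MG ATCC cells for antiproliferative activity against U-87 MG (Homo sapiens), read by MTT assay, with a stated time of 72 h (on this read-out higher numbers stand for weaker inhibition and lower numbers for stronger inhibition), compound 2 gives 750 nM, and the only other measured compound, compound 1, sits within the scatter of it: the step of a 1.4-fold higher number from compound 1 to compound 2 (0.16 log units; within the scatter) is small. Compound 4 `COc1ncc(-c2ccc3nc(NC4CC4)sc3c2)cc1NS(=O)(=O)c1ccc(F)cc1` differs from compound 2 by cyclopropyl in place of (2-(piperidin-1-yl)ethyl)carbamoyl on a nitrogen on an aromatic ring. Going by the values given here, no measured step covers the loss of the carbamoyl part itself; the single available step, a 1.4-fold higher number from compound 1 to compound 2 (0.16 log units; within the scatter), only exchanges groups on the amide-type nitrogen and stays within the scatter, so there is little to anchor a direction. Compound 4 is therefore estimated at 1000 nM, with a range from 300 nM to 3500 nM, and the expected step of a 1.3-fold higher number from compound 2 to compound 4 (0.12 log units; within the scatter) is modest and uncertain in direction.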

Compound 4, half-maximal inhibitory concentration: 1500 nM
Compound 4: the middle estimate sits 1.5-fold (0.18 log units) below what was measured; measured number inside the range.
By their numbers in this assay, from the lowest: compounds 1, 2 and 4 (each within the scatter of the next, the first and the last beyond it).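

In this assay, the carbamoyl part is now taken away with the cyclopropyl kept, and this single change gives a 2.9-fold higher number from compound 1 to compound 4 (0.46 log units; beyond the scatter), a modest loss of inhibition. The larger exchange of (2-(piperidin-1-yl)ethyl)carbamoyl for cyclopropyl on the same nitrogen gives a 2.0-fold higher number from compound 2 to compound 4 (0.30 log units; within the scatter), so it cannot be told apart from repeat scatter. Nothing available explains either step.

As far as these compounds go, whether an acetyl group on this nitrogen would bring the number back to that of compound 1 remains open. So does the effect of a 2-(morpholin-4-yl)ethyl chain there.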